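From 4-nitrophenyl to propyl on the shared core

The compounds below may be only part of what the source reports. "The series", "measured", "known", "first", "only" and "open" are said of these compounds alone.

- compound 1 `Oc1cccc(C(c2c[nH]c3ccc(Br)cc23)c2c[nH]c3ccc(Br)cc23)c1`: 2800 nM
- compound 2 `COc1ccc(C(c2c[nH]c3ccc(Br)cc23)c2c[nH]c3ccc(Br)cc23)cc1OC`: 7800 nM
- compound 3 `O=[N+]([O-])c1ccc(C(c2c[nH]c3ccc(Br)cc23)c2c[nH]c3ccc(Br)cc23)cc1`: 3100 nM

In a functional assay on MCF7 cells (Homo sapiens) for inhibition, read by MTT assay, with a stated time of 48 h (on this read-out higher numbers stand for weaker inhibition and lower numbers for stronger inhibition), compound 3 stands level with compound 1, a 1.1-fold higher number from compound 1 to compound 3 (0.04 log units; within the scatter), and clearly apart from compound 2, a 2.5-fold lower number from compound 2 to compound 3 (0.40 log units; beyond the scatter). Compound 4 `CCCC(c1c[nH]c2ccc(Br)cc12)c1c[nH]c2ccc(Br)cc12` carries propyl in place of 4-nitrophenyl on a saturated chain carbon bound to two aromatic carbons. All three measured steps exchange one phenyl group for another, and the largest, a 2.8-fold higher number from compound 1 to compound 2 (0.44 log units; beyond the scatter), is modest. Within the data shown here, no measured step puts a chain in place of a phenyl group, so this guide is only indirect. Only a small step towards a higher number is expected, a 1.6-fold higher number from compound 3 to compound 4 (0.21 log units; within the scatter). For compound 4 the estimate is 5000 nM, with an expected range from 1800 nM to 14000 nM.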

Compound 4, half-maximal inhibitory concentration: 3600 nM
Estimate against measurement, compound 4: 1.4-fold (0.14 log units) above; low and high end bracket the measured number.
By their numbers in this assay, from the lowest: compounds 1, 3 and 4 (each within the scatter of the next); then compound 2.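

In this assay, among these compounds, propyl is the first chain at this place, on a saturated chain carbon bound to two aromatic carbons, and it shows that a phenyl group is not required for a number at this level: the change gives a 1.2-fold higher number from compound 3 to compound 4 (0.06 log units; within the scatter) and a 1.3-fold higher number from compound 1 to compound 4 (0.11 log units; within the scatter) without leaving the scatter. Only 3,4-dimethoxyphenyl stands apart from propyl, with a 2.2-fold lower number from compound 2 to compound 4 (0.34 log units; beyond the scatter) as the step. Nothing measured here explains this result. The compounds shown leave open whether a longer chain, or a chain ending in an amine or a carboxylic acid, would hold this level. A single propyl compound cannot show how chain length matters at this place.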